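The compounds below may be only part of what the source reports. "The series", "measured", "known", "first", "only" and "open" are said of these compounds alone.

Compound 1 `O=C(NCCNS(=O)(=O)c1ccc(-c2ccccc2Oc2ccc(O)c(O)c2)s1)Nc1cc(Cl)cc(Cl)c1`: in a functional assay on HeLa cells (Homo sapiens) for inhibition, read by CCK-8 assay, with a stated time of 48 h (a lower number here means a stronger inhibitor, a higher number a weaker inhibitor), compound 1 gives > 20000 nM, a limit of the assay rather than a number.
Compound 2 `COc1ccc(Oc2ccccc2-c2ccsc2S(=O)(=O)N2CCN(C(=S)Nc3cc(C(F)(F)F)cc(C(F)(F)F)c3)CC2)cc1OC`: compound 2 gives > 50000 nM, also a limit.
Compound 3 `O=S(=O)(NCCNC(=S)Nc1ccc(Cl)cc1)c1ccc(-c2ccccc2OCc2ccccc2)s1`: compound 3 gives 7000 nM.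

Compound 3 thus stands as the only one of the three with a definite number in this assay; the other two results are limits. Compound 4 `O=[N+]([O-])c1cccc(NC(=S)NCCNS(=O)(=O)c2ccc(-c3ccccc3OCc3ccccc3)s2)c1` is not yet measured. It differs from compound 3 only by 3-nitrophenyl in place of 4-chlorophenyl on an amide-type nitrogen. Going by the values given here, no measured pair among the three compounds shows what this kind of change does, so the step is expected to be small, not beyond the usual scatter, with no clear direction; the expected step is a 1.3-fold higher number from compound 3 to compound 4 (0.11 log units; within the scatter). On that basis compound 4 is estimated at 9000 nM in this assay, with a range from 3000 nM to 30000 nM.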

Compound 4, half-maximal inhibitory concentration: 12800 nM
Compound 4: middle estimate off by 1.4-fold (0.15 log units), on the low side; the range from low to high includes it.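

In this assay, going by these compounds alone, the exchange of 4-chlorophenyl for 3-nitrophenyl on the amide-type nitrogen gives a 1.8-fold higher number from compound 3 to compound 4 (0.26 log units; within the scatter), the first comparison here of compounds that differ in one place. This position therefore accepts both aryl groups with no change that can be told from the scatter. Nothing shown here offers a reason for this step.

Because the group and its ring position change together, the effect of each stays unseparated; 3-chlorophenyl or 4-nitrophenyl would divide them. On these data alone, whether this nitrogen tolerates a non-aromatic group, such as cyclohexyl, or a phenyl ring carrying an amine or a carboxylic acid, also remains open.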